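Shortening a Side Chain to a Bare Hydroxyl

The source may report more compounds than this note shows. Statements on the series, on what has been measured and on what is new or still open speak of the compounds shown alone.

Of the compounds shown here, two built on one shared core have so far been measured in a functional assay for inhibition, with Homo sapiens as the target; a higher number here means a weaker inhibitor, a lower number a stronger inhibitor. Compound 1 `Cc1cc(-c2ccnc(Nc3ccc(N(C)C)cc3)n2)c(C)o1` gives 4900 nM in this assay. Compound 2 `CN(C)CCCOc1ccc(Nc2nccc(-c3cccnc3)n2)cc1` gives 600 nM in this assay, the lower of the two numbers and so the stronger inhibitor of the pair. The gap from compound 2 up to compound 1 is larger than the usual scatter of repeated measurements, so the order of these two is real.

Compound 3 `Oc1ccc(Nc2nccc(-c3cccnc3)n2)cc1` has not yet been measured. It differs from compound 2 in a single place: hydrogen in place of 3-(dimethylamino)propyl on an oxygen on an aromatic ring. Going by the values given here, no measured pair shows this particular change, so its effect is unknown and the expectation rests on the two numbers above alone. Compound 3 is expected to be a somewhat weaker inhibitor than compound 2, estimated at 1500 nM with a likely range from 400 nM to 6000 nM. The step of a 2.5-fold higher number from compound 2 to compound 3 (0.40 log units; beyond the scatter) that this estimate implies is a modest loss, expected to sit only a little beyond the scatter.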

Compound 3, half-maximal inhibitory concentration: 5100 nM
Compound 3: middle estimate off by 3.4-fold (0.53 log units), on the low side; the measured number falls inside the stated range.
By their numbers in this assay, from the lowest: compound 2; then compounds 1 and 3 (each within the scatter of the next).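

Replacing the 3-(dimethylamino)propyl group on the oxygen with hydrogen, which turns 3-(dimethylamino)propoxy into hydroxy, gives an 8.5-fold higher number from compound 2 to compound 3 (0.93 log units; beyond the scatter) in this assay, so this position is sensitive to what it carries. Going by these compounds alone, this is the only pair so far that differs in one place, and it links the stronger inhibition of compound 2 directly to this side chain, with the rest of the structure unchanged. Nothing available explains why the chain matters.

From the compounds shown here alone, what remains open is which part of the chain is responsible. A plain methoxy group, a shorter chain ending in the same dimethylamino group, or a propyl chain ending in a hydroxyl group would help separate the effect of chain length from that of the terminal amine.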